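Swapping the side chain from compound 2 to compound 3

This account rests on a few compounds, and the source may have more. Where it says the series, first, only, none or still open, it means among the compounds named here.

In a functional assay on OVCAR-8 cells (Homo sapiens) for antiproliferative activity (on this read-out higher numbers stand for weaker inhibition and lower numbers for stronger inhibition), compound 1 `Cn1ncc(Cl)c1-c1cc(C(=O)N[C@@H]2CN[C@H](CC(O)CO)C[C@H]2c2ccc(Cl)c(Cl)c2)oc1Cl` gives 1610 nM and compound 2 `Cn1ncc(Cl)c1-c1cc(C(=O)N[C@@H]2CN[C@H](CCN3CCCCC3)C[C@H]2c2ccc(Cl)c(Cl)c2)oc1Cl` gives 1660 nM, so the two stand level within the scatter. Compound 3 `Cn1ncc(Cl)c1-c1cc(C(=O)N[C@@H]2CN[C@H](CC(N)=O)C[C@H]2c2ccc(Cl)c(Cl)c2)oc1Cl` carries carbamoyl in place of (piperidin-1-yl)methyl on a saturated chain carbon bound to a saturated ring carbon. Among the compounds with values here, the one measured step at this place, a 1.0-fold higher number from compound 1 to compound 2 (0.01 log units; within the scatter), lies within the scatter, and it is the only guide. No step beyond the scatter is therefore expected in this assay, and the expected change is a 1.0-fold lower number from compound 2 to compound 3 (0.02 log units; within the scatter). Compound 3 is estimated at 1600 nM, with an expected range of 700 nM to 3500 nM.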

Compound 3, half-maximal inhibitory concentration: 1000 nM
Compound 3: middle estimate off by 1.6-fold (0.20 log units), on the high side; the range from low to high includes it.
By their numbers in this assay, from the lowest: compounds 3, 1 and 2 (each within the scatter of the next).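

In this assay, carbamoyl in place of (piperidin-1-yl)methyl gives a 1.7-fold lower number from compound 2 to compound 3 (0.22 log units; within the scatter), and carbamoyl in place of 1,2-dihydroxyethyl gives a 1.6-fold lower number from compound 1 to compound 3 (0.21 log units; within the scatter), so neither step leaves the scatter. On this saturated chain carbon bound to a saturated ring carbon, a group with no ring therefore stands level with the piperidine-bearing group and the diol. On these data alone, whether any group here can move the number beyond the scatter stays open, for example a carboxylic acid or a primary amine. No available evidence bears on the cause of this result.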